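This account rests on a few compounds, and the source may have more. Where it says the series, first, only, none or still open, it means among the compounds named here.

Measured so far in an ADME assay on J774 cells (Mus musculus) for cytotoxicity; on this read-out lower numbers stand for an effect already at smaller amounts and higher numbers for an effect only at larger amounts of compound:

Compound 1, `COC(=O)c1c[nH]c2ccc(C(C)C)cc2c1=O`, gives only a limit of the assay, > 20000 nM.
Compound 2, `CCc1ccc2[nH]cc(C(=O)OC)c(=O)c2c1`, likewise gives only a limit, > 20000 nM.
Compound 3, `CCc1cc2c(=O)c(C(=O)OC)c[nH]c2cc1OCCOc1ccccc1`, also gives only a limit, > 20000 nM.

From compound 2 to compound 1 the change is methyl in place of hydrogen on a saturated chain carbon bound to an aromatic carbon and a saturated chain carbon; the step it made is a step that the two limits leave unreadable from compound 2 to compound 1, unreadable because of the limit of > 20000 nM in this assay, at which 3 of the 3 values shown sit. How the cores of compound 2 and compound 3 differ is not broken down here.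

Compound 4, `CCCc1cc2c(=O)c(C(=O)OC)c[nH]c2cc1OCCOc1ccccc1`, is not yet measured in this assay. It differs from compound 3 by methyl in place of hydrogen on a saturated chain carbon, two bonds along the chain from an aromatic carbon. This is the same kind of change as that from compound 2 to compound 1, but around the place it differs: in compound 1 the carbon is bound to an aromatic carbon and a saturated chain carbon, in compound 4 it lies two bonds along the chain from an aromatic carbon.

For compound 4 the expected step is a step that the limit leaves unreadable from compound 3 to compound 4, resting on (the limit of > 20000 nM in this assay, at which 3 of the 3 values shown sit). Compound 4 is therefore estimated at 30000 nM, most likely again only a limit.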

Compound 4, half-maximal effective concentration: > 20000 nM
Compound 4: a limit, no number; the forecaster's own chance of this, stated with the estimate: 85%; the middle value does not contradict the limit.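

No step can be read between compound 3 and compound 4 because both stand at a limit: the limit of > 20000 nM in this assay, at which 4 of the 4 values shown sit.

The compounds shown leave open whether the change from ethyl to propyl moves this read-out at all, and in which direction.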